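Aryl swap on the triazole nitrogen: compound 3 to compound 4

A few compounds are considered here, and "the series" means these few. Any claim that something is new, unique, unknown or untested is made for them only; others in the source may bear on it.

Measured so far:
- compound 1 `Cc1ccc(C)c(-n2nncc2CN2C(=O)C3(C(C#N)=C(N)Oc4c3c3nc5ccccc5nc3c3ccccc43)c3ccccc32)c1`; in a functional assay on HCT-116 cells (Homo sapiens) for antiproliferative activity, read by MTT assay, with a stated time of 48 h (a higher number here means a weaker inhibitor, a lower number a stronger inhibitor), compound 1 gives > 50000 nM, a limit of the assay.
- compound 2 `Cc1ccc(Cl)cc1-n1nncc1CN1C(=O)C2(C(C#N)=C(N)Oc3c2c2nc4ccccc4nc2c2ccccc32)c2ccccc21`; in this assay compound 2 gives > 50000 nM, a limit.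
- compound 3 `N#CC1=C(N)Oc2c(N)cc3nc4ccccc4nc3c2C12C(=O)N(Cc1cnnn1-c1ccc(F)cc1)c1ccccc12`; in this assay compound 3 gives > 50000 nM, a limit.

Compound 3 thus stands at the limit, as do both other measured compounds: the limit of > 50000 nM in this assay, at which 3 of the 3 values shown sit. Compound 4 `COc1ccc(OC)c(-n2nncc2CN2C(=O)C3(C(C#N)=C(N)Oc4c(N)cc5nc6ccccc6nc5c43)c3ccccc32)c1` differs from compound 3 by 2,5-dimethoxyphenyl in place of 4-fluorophenyl on an aromatic nitrogen.

Within the data shown here, the only measured step, a step that the two limits leave unreadable from compound 1 to compound 2, runs between two limits and its size cannot be read; it also concerns an aromatic carbon, not the aromatic nitrogen changed here. Among the measured compounds shown here, no measured step therefore informs the present change, and the default expectation is that compound 4 stays at the limit. The step that the limit leaves unreadable from compound 3 to compound 4 is expected to be small or unreadable. For compound 4 an estimate of 70000 nM is given, with a range of 25000 nM to 200000 nM.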

Compound 4, half-maximal inhibitory concentration: > 50000 nM
Compound 4 gave a limit, no number (the forecaster's own chance of this, stated with the estimate: 85%); the middle value lies beyond the limit too.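

In this assay compound 4 gives > 50000 nM, a limit, so the step from compound 3 to compound 4 cannot be read. The compounds shown leave open whether any aryl group on the aromatic nitrogen gives a readable value: the limit of > 50000 nM in this assay, at which 4 of the 4 values shown sit.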